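Swapping a Cyclopropyl for a Sulfonamide Arm

This account rests on a few compounds, and the source may have more. Where it says the series, first, only, none or still open, it means among the compounds named here.

Compound 1 `COc1ccc(-c2cn(C/C=C3\OC(=O)C(OCc4ccccc4)=C3OCc3ccccc3)nn2)cc1` gives in a functional assay on CFPAC-1 cells (Homo sapiens) for antiproliferative activity, read by MTT assay, with a stated time of 72 h (on this read-out higher numbers stand for weaker inhibition and lower numbers for stronger inhibition), only a limit, > 100000 nM.
Compound 2 `CCCCCCCCCCc1cn(C[C@H](O)[C@H]2OC(=O)C(OCc3ccccc3)=C2OCc2ccccc2)nn1` gives 40300 nM.
Compound 3 `O=C1O[C@H]([C@@H](O)Cn2cc(C3CC3)nn2)C(OCc2ccccc2)=C1OCc1ccccc1` gives 47700 nM.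

Of the two real numbers, compound 3 sits alongside compound 2, since a 1.2-fold higher number from compound 2 to compound 3 (0.07 log units; within the scatter) is within the scatter; the two cannot be ordered. Compound 4 `Cc1ccc(S(=O)(=O)NCc2cn(C[C@H](O)[C@H]3OC(=O)C(OCc4ccccc4)=C3OCc3ccccc3)nn2)cc1` carries (((4-methylphenyl)sulfonyl)amino)methyl in place of cyclopropyl on an aromatic carbon. For the measured compounds named here, the only measured step touching this position exchanged one carbon group for another and barely moved the number; the entering sulfonyl-bearing arm is a larger change, so that step is an uncertain guide. Compound 4 is therefore expected to stay near compound 3, with an estimated step of a 1.1-fold lower number from compound 3 to compound 4 (0.03 log units; within the scatter) and an expected value of 45000 nM, ranging from 15000 nM to 100000 nM.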

Compound 4, half-maximal inhibitory concentration: 68000 nM
Compound 4: middle estimate off by 1.5-fold (0.18 log units), on the low side, and the stated range covers the measured number.
By their numbers in this assay, from the lowest: compounds 2, 3 and 4 (each within the scatter of the next). At a limit, above all of these: compound 1.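

Replacing cyclopropyl with the far larger (((4-methylphenyl)sulfonyl)amino)methyl arm gives a 1.4-fold higher number from compound 3 to compound 4 (0.15 log units; within the scatter) so even an arm with an added aromatic ring and a hydrogen-bond donor does not separate the two compounds. Against the long chain the result is the same, with a 1.7-fold higher number from compound 2 to compound 4 (0.23 log units; within the scatter) and so three very different groups on this aromatic carbon give numbers that cannot be ordered. No measurement shown bears on why this position responds so little. On these data alone, whether a free amine or a carboxylic acid on this carbon would move the number beyond the scatter remains open.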